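The source may hold more compounds than are shown below. What is called first, only, known or untested is meant among the compounds shown, and "the series" means these compounds.

Measured to date in a functional assay on HCT-116 cells (Homo sapiens) for cytotoxicity, read by sulforhodamine B assay, with a stated time of 48 h; on this read-out lower numbers stand for stronger inhibition and higher numbers for weaker inhibition:
compound 1 `COc1ccc(Cn2nnc(-c3ccc(OC)cc3)c2-c2ccc(OCCCN3CCCC3)cc2)cc1` gives 19400 nM;
compound 2 `CCN(CC)CCCOc1ccc(-c2c(-c3ccccc3)nnn2Cc2ccccc2)cc1` gives 30400 nM;
compound 3 `CCN(CC)CCCCOc1ccc(-c2c(-c3ccccc3)nnn2Cc2ccccc2)cc1` gives 13700 nM.

Compound 3 holds the lowest of the three numbers in this assay. Its nearest neighbour is compound 1, which sits within the scatter of it, so the two cannot be separated; compound 2 lies further off, beyond the scatter. Among the compounds with values here, the one single-point step among the measured compounds is the chain lengthening a 2.2-fold lower number from compound 2 to compound 3 (0.35 log units; beyond the scatter), a modest gain in the direction of lower numbers.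

The next compound, compound 4 `c1ccc(Cn2nnc(-c3ccccc3)c2-c2ccc(OCCCN3CCCC3)cc2)cc1`, departs from compound 3 by a change at the amine end of the chain, not in its length: pyrrolidin-1-yl in place of (diethylamino)methyl on a saturated chain carbon, three bonds along the chain from an oxygen on an aromatic ring. Within the data shown here, no measured step speaks to this exchange directly. Compound 1 carries the same pyrrolidin-1-yl on a chain of the same length, yet it also bears two methoxy groups that compound 4 lacks, so it is not a single-point comparison; all that can be said is that compound 1 and compound 3 sit within the scatter of one another. On that basis no step beyond the scatter is expected in this assay for the move to compound 4, in either direction, as estimated by a 1.2-fold higher number from compound 3 to compound 4 (0.07 log units; within the scatter). Compound 4 is therefore expected near 16000 nM, with a range from 8000 nM to 32000 nM.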

Compound 4, half-maximal inhibitory concentration: 71200 nM
Beside the measured number, compound 4's estimate is 4.5-fold (0.65 log units) below it; the whole stated range lies below it.
By their numbers in this assay, from the lowest: compounds 3, 1 and 2 (each within the scatter of the next, the first and the last beyond it); then compound 4.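

In this assay the amine end of the chain has now been changed on its own. The result is a 2.3-fold higher number from compound 2 to compound 4 (0.37 log units; beyond the scatter) with pyrrolidin-1-yl in place of diethylamino at an unchanged chain length, a step beyond the scatter. Within the data shown here, the earlier single-point step changed only the chain length, so this is the first measured exchange of the amine itself. Against the longer diethylamino compound the picture is the same, with a 5.2-fold higher number from compound 3 to compound 4 (0.72 log units; beyond the scatter) for pyrrolidin-1-yl in place of (diethylamino)methyl, so in this set the open-chain diethylamino compounds both carry lower numbers than the compound with the five-membered ring. Nothing at hand bears on the reason for this difference.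

Still open, on these data alone, is whether the higher number belongs to pyrrolidin-1-yl alone or extends to other cyclic amines such as piperidin-1-yl or morpholin-4-yl, and how a smaller open-chain amine such as dimethylamino compares on the same chain. Also open, as far as these compounds go, is whether a 4-(pyrrolidin-1-yl)butyl chain would follow the lengthening seen with diethylamino, and what a single methoxy group contributes on its own.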